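Amide nitrogen substituent: compound 1 to compound 4

The compounds below may be only part of what the source reports. "The series", "measured", "known", "first", "only" and "open" are said of these compounds alone.

Measured values in a functional assay on MCF7 cells (Homo sapiens) for antiproliferative activity; a higher number here means a weaker inhibitor, a lower number a stronger inhibitor:

compound 1 `CCONC(=O)c1sc(N2N=C(c3ccc(C)cc3)CC2c2cc3cc(OC)ccc3nc2Cl)nc1C`: 38 nM
compound 2 `Cc1ccc(S(=O)(=O)Oc2ccc(Cl)c3cccnc23)cc1`: 1380 nM
compound 3 `Cc1cc(S(=O)(=O)c2ccccc2[N+](=O)[O-])c2ccccc2n1`: 1380 nM

Compound 1 stands lowest of the three numbers. Its nearest neighbour is compound 2, whose value in this assay lies well beyond the scatter above it; compound 3 sits at the same distance, so compound 2 and compound 3 show the same number and cannot be ordered against each other. Among the compounds with values here, compound 2 and compound 3 share no core with compound 1, and no single-point step between any two measured compounds is available to calibrate how much one change of a substituent moves the read-out.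

Compound 4 `CNC(=O)c1sc(N2N=C(c3ccc(C)cc3)CC2c2cc3cc(OC)ccc3nc2Cl)nc1C` is the next compound for this assay. Against compound 1 the difference is methyl in place of ethoxy on an amide-type nitrogen. The rest of the molecule is untouched.

Within the data shown here, with no measured step of comparable kind in hand, the expectation rests on compound 1 alone, whose value is 38 nM. For compound 4 the estimated change is a 1.2-fold higher number from compound 1 to compound 4 (0.07 log units; within the scatter), that is, no step beyond the scatter in either direction is expected. Compound 4 is therefore expected near 45 nM, with a range from 15 nM to 150 nM.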

Compound 4, half-maximal inhibitory concentration: 38 nM
Beside the measured number, compound 4's estimate is 1.2-fold (0.07 log units) above it, and the stated range covers the measured number.
By their numbers in this assay, from the lowest: compounds 1 and 4 (each within the scatter of the next); then compounds 2 and 3 (each within the scatter of the next).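

In this assay, within the data shown here, the exchange of ethoxy for methyl on the amide-type nitrogen reads as no change at the digits printed from compound 1 to compound 4 (within the scatter) and is the first single-point step available, which until now offered only compounds with no core in common. At this position the read-out stays within the scatter whether the nitrogen carries ethoxy or methyl, so for this pair the oxygen of the ethoxy group and the larger of the two substituents are not needed to keep a value at this level on the shared core. Nothing at hand bears on why the two compounds read alike, and the pair alone offers no explanation.

Only ethoxy and methyl are shown on this nitrogen, so it remains open whether the same holds for a plain amide hydrogen, a longer chain such as n-butyl, a benzyl group, or a dimethylaminoethyl chain carrying an amine. One step at one position also leaves open how far the read-out moves when other parts of the shared core are changed, such as the chloro or methoxy substituents.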